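Ethoxycarbonyl to acetyl: what half-life to expect

The compounds below may be only part of what the source reports. "The series", "measured", "known", "first", "only" and "open" are said of these compounds alone.

Three compounds have a measured half-life so far in an ADME assay on a cell-free system (plasma, Homo sapiens) for metabolic stability, read by HPLC (a lower number here means that the compound disappears faster, a higher number that the compound lasts longer), of this series. Compound 1 (`COC(=O)c1ccc(/N=N/N(C)C(=O)CCc2cccc(O)c2)cc1`) gives 7.8 h and compound 2 (`CN(/N=N/c1ccc(C#N)cc1)C(=O)CCCCc1ccc(O)cc1`) gives 11.8 h on this scale. Compound 3 (`CCOC(=O)c1ccc(/N=N/N(C)C(=O)CCCCc2ccc(O)cc2)cc1`) gives 26.3 h as the highest of the three numbers, with compound 2 the nearest and compound 1 the furthest below it.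

The next compound is compound 4 (`CC(=O)c1ccc(/N=N/N(C)C(=O)CCCCc2ccc(O)cc2)cc1`), which has methyl in place of ethoxy on a carbonyl carbon, so that ethoxycarbonyl turns to acetyl (methyl in place of ethoxy on a carbonyl carbon). Among the compounds with values here, one measured step touches this group, namely a 2.2-fold higher number from compound 2 to compound 3 (0.35 log units; beyond the scatter) with ethoxycarbonyl in place of cyano on an aromatic carbon. That step is modest but beyond the scatter. Compound 1 differs from compound 3 in more than one place and offers no clean comparison. Within the data shown here, no measured compound carries acetyl, so the evidence is indirect. Acetyl is expected to land below ethoxycarbonyl but near or above cyano, with compound 2 at 11.8 h as the lower guide. The expected change is a 1.5-fold lower number from compound 3 to compound 4 (0.19 log units; within the scatter) and is smaller than the step from cyano to ethoxycarbonyl. For compound 4 the estimated half-life is 17 h within an expected range from 8 h to 34 h once it is measured.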

Compound 4, half-life in the plasma assay: 32.7 h
Estimate against measurement, compound 4: 1.9-fold (0.28 log units) below, within the range that was stated.
By their numbers in the plasma assay, from the lowest: compounds 1 and 2 (each within the scatter of the next); then compounds 3 and 4 (each within the scatter of the next).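

In the plasma assay the replacement of ethoxycarbonyl by acetyl gives a 1.2-fold higher number from compound 3 to compound 4 (0.09 log units; within the scatter) and so does not separate the two groups, even though 3 heavy atoms leave and 1 enters on the carbonyl carbon. This position therefore tolerates the loss of ethoxy in the plasma assay, while the group on the aromatic carbon still matters: the earlier step (a 2.2-fold higher number from compound 2 to compound 3 (0.35 log units; beyond the scatter)) now has a companion (a 2.8-fold higher number from compound 2 to compound 4 (0.44 log units; beyond the scatter)), and among the three compounds that differ in this one place, only the cyano compound stands apart from the others. In a physicochemical assay, read by HPLC, in phosphate buffer, with a stated time of 8 days, at pH 7.4 (a higher number here means that more of the compound is left, a lower number that less of the compound is left), the same change gives no change at the digits printed from compound 3 to compound 4 (within the scatter) (compound 3 at 100% and compound 4 at 100%), so neither group sets these two compounds apart in that assay.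

Nothing shown here explains why cyano differs from the two carbonyl groups or why those two match. From the compounds shown here alone, it remains open whether the same level holds for a carboxylic acid or a primary amide on the aromatic carbon, or for a longer chain than ethoxy on the carbonyl carbon.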